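The source may report more compounds than this note shows. Statements on the series, on what has been measured and on what is new or still open speak of the compounds shown alone.

Measured compounds:
- compound 1 `CC#C[C@H]1CN(S(=O)(=O)c2ccc(N)nc2)CCN1c1ccc(S(=O)(=O)NCC2CC2)cc1`: 213 mL.min-1.g-1
- compound 2 `CC#C[C@H]1CN(S(=O)(=O)c2ccc(N)nc2)CCN1c1ccc(S(=O)(=O)NC)cn1`: 42 mL.min-1.g-1
- compound 3 `CC#C[C@H]1CN(S(=O)(=O)c2ccc(N)nc2)CCN1c1ncc(C(C)(O)C(F)(F)F)s1`: 87 mL.min-1.g-1

In an ADME assay (liver) for metabolic stability, with Liver microsome (Rattus norvegicus) as the target, using microsomes and NADPH, with a stated time of 30 min (on this read-out lower numbers stand for slow clearance and higher numbers for fast clearance), compound 1 gives 213 mL.min-1.g-1, the highest of the three numbers. Compound 3 stands nearest, with 87 mL.min-1.g-1, a gap beyond the scatter. Compound 2 stands furthest, with 42 mL.min-1.g-1, also beyond the scatter. For the measured compounds named here, no step between two measured compounds differing in one place is available, so the move to compound 4 `CC#C[C@H]1CN(S(=O)(=O)c2ccc(N)nc2)CCN1c1ccc([C@](O)(CO)C(F)(F)F)cc1` rests on the shared core alone. The change is 1,2-dihydroxy-1-(trifluoromethyl)ethyl in place of (cyclopropylmethyl)sulfamoyl on an aromatic carbon. Given that compound 1 stands highest and both other members of the series fall below it, a step downward beyond the scatter is expected, towards slower clearance. For compound 4 the estimate is 80 mL.min-1.g-1, range 35 mL.min-1.g-1 to 180 mL.min-1.g-1, an expected step of a 2.7-fold lower number from compound 1 to compound 4 (0.43 log units; beyond the scatter).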

Compound 4, intrinsic clearance in microsomes: < 14 mL.min-1.g-1
Compound 4: a limit, no number; the forecaster's own chance of this, stated with the estimate: 5%; at least 5.7-fold (0.75 log units) between middle value and limit.
By their numbers in this assay, from the lowest: compound 2; then compound 3; then compound 1. At a limit, below all of these: compound 4.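

In this assay compound 4 gives a limit and not a number: the limit of < 14 mL.min-1.g-1 in this assay, at which 1 of the 4 values shown sits. Setting 1,2-dihydroxy-1-(trifluoromethyl)ethyl in place of (cyclopropylmethyl)sulfamoyl on this aromatic carbon gives an at least 15-fold lower number from compound 1 to compound 4 (1.18 log units; beyond the scatter), the first step in the series that can be read at a single place. The clearance read-out on the shared core therefore responds strongly to the group at this position.

The hydroxyl groups, the trifluoromethyl and the loss of the cyclopropyl ring all change together, so the step cannot be assigned to any one of them. On these data alone, whether a simple hydroxymethyl or a carboxylic acid at this position would give a similar step remains open.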